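Shortening a Selenium-Bound Chain on a Shared Core

The compounds below may be only part of what the source reports. "The series", "measured", "known", "first", "only" and "open" are said of these compounds alone.

Compound 3 `CCCCC[Se]c1nc(NCc2ccccc2)c2ccccc2n1` is one of three compounds tested in an ADME assay on BEAS-2B cells (Homo sapiens) for cytotoxicity, read by MTT assay, with a stated time of 72 h; on this read-out lower numbers stand for stronger inhibition of growth and higher numbers for weaker inhibition of growth. In this assay compound 3 gives > 100000 nM, which is a limit of the assay and not a number. Compound 1 `CCCCC[Se]c1nc(NCc2ccc(SC)cc2)c2ccccc2n1` gives 88200 nM in this assay. Compound 2 `CCCCC[Se]c1nc([Se]CCCCC)c2ccccc2n1` gives > 100000 nM in this assay, which is again a limit. Compound 3 therefore stands at the weak end of what the assay can report, as does compound 2, while compound 1 alone gives a numbered value.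

Compound 4 `C[Se]c1nc(NCc2ccccc2)c2ccccc2n1` differs from compound 3 in one place: hydrogen in place of butyl on a saturated chain carbon bound to a selenium atom. Among the measured compounds shown here, none of the measured steps touches this chain. The step of an at least 1.1-fold higher number from compound 1 to compound 3 (0.05 log units; that floor lies within the scatter) concerns a different group and is too small to read as a change, and the step that the two limits leave unreadable from compound 2 to compound 3 cannot be read at all because of the limit of > 100000 nM in this assay, at which 2 of the 3 values shown sit. With two of three values sitting at that limit, compound 4 is expected most likely to reach no numbered value in this assay either, and no step beyond the scatter is expected.

Compound 4 is estimated at 100000 nM in this assay, within 40000 nM to 300000 nM. The step this estimate means, a number no higher from compound 3 to compound 4 (the limit leaves the size open), is expected to be none beyond the scatter.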

Compound 4, concentration for total growth inhibition: 37000 nM
Compound 4: middle estimate off by 2.7-fold (0.43 log units), on the high side; the measured number lies below the stated range.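

Read as pentyl to methyl, this change on a saturated chain carbon bound to a selenium atom gives the first step in this assay that can be read as beyond the scatter: an at least 2.7-fold lower number from compound 3 to compound 4 (0.43 log units; beyond the scatter). On this read-out, a lower number means stronger inhibition of growth, so the shorter chain goes with stronger inhibition of these cells, whereas neither earlier step could show a clear change at any position. Going by these compounds, the real size of the step remains open because compound 3 sits at a limit of the assay and not at a number: the limit of > 100000 nM in this assay, at which 2 of the 4 values shown sit.

With only the pentyl and methyl ends of the series shown, this is a single comparison and not a trend, so it remains open whether an ethyl or propyl chain would give a value lying between those of compound 3 and compound 4, or whether the change would build steadily with chain length. On these data alone, it is also open how a chain of a different kind in this place, such as one ending in an amine or a carboxylic acid, would behave, and whether the same shortening would have a similar effect with a different group on the shared core.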